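From 4-fluorophenyl to 3-fluorophenyl on a carbonyl carbon

This account rests on a few compounds, and the source may have more. Where it says the series, first, only, none or still open, it means among the compounds named here.

Of the compounds shown here, three with a shared core have been read in a toxicity assay on THP-1 cells (Homo sapiens) for inhibition (on this read-out lower numbers stand for higher toxicity in this test and higher numbers for lower toxicity in this test), and none of them has yet given a number. Compound 1 `COc1ccc(-c2cnc(NC(=O)C3CCNCC3)n2C)cc1`, with piperidin-4-yl on the carbonyl carbon, gives only a limit, > 100000 nM. Compound 2 `COc1ccc(-c2cnc(NC(=O)c3ccccc3C)n2C)cc1`, with 2-methylphenyl in that place, also gives a limit, > 100000 nM. Compound 3 `COc1ccc(-c2cnc(NC(=O)c3ccc(F)cc3)n2C)cc1`, with 4-fluorophenyl there, stands at a limit as well, >= 50000 nM. The whole set therefore consists of limits: the limit of > 100000 nM in this assay, at which 2 of the 3 values shown sit, and (the limit of >= 50000 nM in this assay, at which 1 of the 3 values shown sits).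

Compound 4 `COc1ccc(-c2cnc(NC(=O)c3cccc(F)c3)n2C)cc1`, not yet measured, differs from compound 3 in one place: 3-fluorophenyl in place of 4-fluorophenyl on a carbonyl carbon. Here 3-fluorophenyl stands in place of 4-fluorophenyl on a carbonyl carbon.

The closest measured change is a step that the two limits leave unreadable from compound 2 to compound 3. The two changes away from piperidin-4-yl offer no more, being a step that the two limits leave unreadable from compound 1 to compound 2 and a step that the two limits leave unreadable from compound 1 to compound 3. With no readable size among these steps, no step beyond the scatter is expected in this assay, and no direction can be given. The expected change is a step that the limit leaves unreadable from compound 3 to compound 4. Compound 4 is estimated at 70000 nM, with an expected range from 30000 nM to 150000 nM.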

Compound 4, half-maximal cytotoxic concentration: > 100000 nM
Compound 4 gave a limit, no number; the forecaster's own chance of this, stated with the estimate: 80%; at least 1.4-fold (0.15 log units) between middle value and limit.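

In this assay, compound 4 gives only a limit, > 100000 nM, so the steps to it from compound 1, compound 2 and compound 3 cannot be read. The compounds shown leave open whether piperidin-4-yl, 2-methylphenyl, 4-fluorophenyl and 3-fluorophenyl on the carbonyl carbon differ at all in this assay, as all four values are limits.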